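From Compound 2 to the Carboxy Compound 4

The compounds below may be only part of what the source reports. "The series", "measured", "known", "first", "only" and "open" are said of these compounds alone.

Values in an ADME assay on microsomes from liver (Homo sapiens) for metabolic stability, with a stated time of 10 min; on this read-out lower numbers stand for a less stable compound and higher numbers for a more stable compound:
- compound 1 `CC(=O)N1CCC(C)(C(=O)N2CC[C@](c3ccc(C(OCc4c(F)cccc4F)(C(F)(F)F)C(F)(F)F)cc3)(S(=O)(=O)c3ccc(F)cc3)C2)CC1`: 1%
- compound 2 `CC(=O)N1CCC(O)(C(=O)N2CC[C@](c3ccc(C(OCc4c(F)cccc4F)(C(F)(F)F)C(F)(F)F)cc3)(S(=O)(=O)c3ccc(F)cc3)C2)CC1`: 16%
- compound 3 `CC(=O)N1CCN(C(=O)N2CC[C@](c3ccc(C(OCc4c(F)cccc4C#N)(C(F)(F)F)C(F)(F)F)cc3)(S(=O)(=O)c3ccc(F)cc3)C2)CC1`: 0%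

Of these three, compound 2 stands highest in this assay at 16%. Compound 4 `O=C(O)C1CCN(C(=O)N2CC[C@](c3ccc(C(OCc4c(F)cccc4F)(C(F)(F)F)C(F)(F)F)cc3)(S(=O)(=O)c3ccc(F)cc3)C2)CC1` carries 4-carboxypiperidin-1-yl in place of 1-acetyl-4-hydroxypiperidin-4-yl on a carbonyl carbon. Among the compounds with values here, only one measured step touches this group, a number 15 percentage points higher from compound 1 to compound 2 (beyond the scatter), and it is modest and beyond the scatter. Within the data shown here, no measured compound carries the entering group, so that step is only a weak guide. On that slender basis, a further rise of at least similar size is expected, with wide uncertainty. The expected change is a number 29 percentage points higher from compound 2 to compound 4 (beyond the scatter). For compound 4 the estimated value is 45%, within an expected range of 12% to 85%.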

Compound 4, percent of the compound remaining: 72%
The estimate for compound 4 lay 27 percentage points below the measured number; low and high end bracket the measured number.
By their numbers in this assay, from the lowest: compounds 3 and 1 (each within the scatter of the next); then compound 2; then compound 4.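

In this assay, the group on the carbonyl carbon turns out to allow far more change than the earlier hydroxy-for-methyl swap showed, which was modest (a number 15 percentage points higher from compound 1 to compound 2 (beyond the scatter)). Here, 4-carboxypiperidin-1-yl in place of 1-acetyl-4-hydroxypiperidin-4-yl gives a large step (a number 56 percentage points higher from compound 2 to compound 4 (beyond the scatter)), and in place of 1-acetyl-4-methylpiperidin-4-yl a larger one still (a number 71 percentage points higher from compound 1 to compound 4 (beyond the scatter)). Nothing at hand accounts for these rises. On these data alone, the swap replaces the whole group, so whether the carboxylic acid alone carries the gain stays open. So does what a methyl ester or a primary amide would give in its place.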